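Methyl for Fluoro: Expectation for Compound 4

The compounds below may be only part of what the source reports. "The series", "measured", "known", "first", "only" and "open" are said of these compounds alone.

In an assay on cells for inhibition of Palmitoleoyl-protein carboxylesterase NOTUM variant C330S (Homo sapiens), read by fluorescence, with a stated time of 40 min (on this read-out lower numbers stand for stronger inhibition and higher numbers for weaker inhibition), three compounds have been measured:
compound 1 `Cc1cc(C(=O)O)c(C)n1-c1cccc(C#N)c1F` gives 630 nM
compound 2 `Cc1cc(C(=O)O)c(C)n1-c1ccccc1F` gives 3300 nM
compound 3 `Cc1cc(C(=O)O)c(C)n1-c1cccc(Cl)c1C#N` gives 2000 nM

Compound 2 stands at the high end of these numbers. Its gap to compound 3 lies within the scatter, so the two cannot be ordered. Against compound 1 the step is a 5.2-fold higher number from compound 1 to compound 2 (0.72 log units; beyond the scatter), the only one-place step among the measured compounds. Compound 4 `Cc1ccccc1-n1c(C)cc(C(=O)O)c1C` differs from compound 2 by methyl in place of fluoro on an aromatic carbon. Among the measured compounds shown here, no measured step bears on a fluoro-to-methyl exchange at this position, and the one step that exists concerns a different group. Compound 4 is therefore expected to stay near compound 2, with no step beyond the scatter, a 1.3-fold lower number from compound 2 to compound 4 (0.12 log units; within the scatter). In this assay compound 4 is estimated at 2500 nM, with a range from 900 nM to 7000 nM.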

Compound 4, half-maximal inhibitory concentration: 2200 nM
The estimate for compound 4 lay 1.1-fold (0.06 log units) above the measured number; low and high end bracket the measured number.
By their numbers in this assay, from the lowest: compound 1; then compounds 3, 4 and 2 (each within the scatter of the next).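

In this assay, methyl in place of fluoro on an aromatic carbon, ortho to a large group, gives a 1.5-fold lower number from compound 2 to compound 4 (0.18 log units; within the scatter), so the two groups cannot be told apart at this place. This is the first exchange shown at this position, as the earlier step concerned cyano. No evidence is available that bears on this result.

As far as these compounds go, it remains open whether an amine, a methoxy group or a longer chain here would move the number beyond the scatter. From the compounds shown here alone, whether cyano would give compound 4 a step like the one in a 5.2-fold higher number from compound 1 to compound 2 (0.72 log units; beyond the scatter) also remains open.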